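A few compounds are considered here, and "the series" means these few. Any claim that something is new, unique, unknown or untested is made for them only; others in the source may bear on it.

Compound 1 `Cc1nc(N)c2c(-c3ccccc3)cn([C@@H]3O[C@H](CO)[C@@H](O)[C@H]3O)c2n1`: in a functional assay on HCT-116 cells (Homo sapiens), read by MTT assay, with a stated time of 72 h (on this read-out higher numbers stand for weaker inhibition and lower numbers for stronger inhibition), compound 1 gives > 100000 nM, which is a limit of the assay rather than a number.
Compound 2 `Cc1nc(N)c2c(-c3cccs3)cn([C@@H]3O[C@H](CO)[C@@H](O)[C@H]3O)c2n1`: in this assay compound 2 gives > 20000 nM, again a limit of the assay.
Among the compounds with values here, compound 3 `COc1ncnc2c1c(-c1cccs1)cn2[C@@H]1O[C@H](CO)[C@@H](O)[C@H]1O`: in this assay compound 3 gives 80 nM, the only number among the three.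

Compound 1 and compound 2 share one core and differ by phenyl in place of thiophen-2-yl on an aromatic carbon. Since both sit at limits, the limit of > 100000 nM in this assay, at which 1 of the 3 values shown sits, and (the limit of > 20000 nM in this assay, at which 1 of the 3 values shown sits), the step that the two limits leave unreadable from compound 2 to compound 1 cannot be read in size. Compound 3 carries a different core, and the difference between the two cores is not broken down here.

Compound 4 `COc1ncnc2c1c(-c1ccccc1)cn2[C@@H]1O[C@H](CO)[C@@H](O)[C@H]1O` has not been measured. It is made from compound 3 by phenyl in place of thiophen-2-yl on an aromatic carbon, the same change as between compound 2 and compound 1, since the place is the same word for word. With that earlier step unreadable, the expectation for compound 4 rests mainly on compound 3 giving 80 nM; the step of a 1.9-fold higher number from compound 3 to compound 4 (0.27 log units; within the scatter) is expected to stay modest. Compound 4 is thus estimated at 150 nM in this assay, between 40 nM and 800 nM.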

Compound 4, half-maximal inhibitory concentration: > 20000 nM
Compound 4: a limit, no number (the forecaster's own chance of this, stated with the estimate: 5%); middle value at least 130-fold (2.12 log units) away from the limit.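

In this assay, phenyl in place of thiophen-2-yl on an aromatic carbon gives an at least 250-fold higher number from compound 3 to compound 4 (2.39 log units; beyond the scatter) on the core of compound 3, so on this core the swap is far from neutral. Compound 4 gives a limit of the assay rather than a number, which leaves the full size of the step unknown: the limit of > 20000 nM in this assay, at which 2 of the 4 values shown sit. The same change on the core of compound 1 cannot be read, with compound 1 and compound 2 both at limits, so these compounds show a large step on one core but neither confirm nor contradict it on the other.

On these data alone, it remains open how furan-2-yl, a methyl group or an amine would behave at this same place on the core of compound 3. As far as these compounds go, it also remains open whether any group there would give a readable number on the core of compound 1, which would allow a real comparison between the two cores.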